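The compounds below may be only part of what the source reports. "The series", "measured", "known", "first", "only" and "open" are said of these compounds alone.

In a functional assay on Jurkat cells for inhibition of nuclear factor NF-kappa-B complex (Homo sapiens) (a lower number here means a stronger inhibitor, a higher number a weaker inhibitor), compound 3 `CCOC(=O)c1cnc(C(=O)c2ccco2)nc1NN1C(=O)C=C(C)C1=O` gives 700 nM, the second highest of the three numbers; its nearest neighbour is compound 2 `CCOC(=O)c1cnc(-c2cc3ccccc3s2)nc1NN1C(=O)C=C(C)C1=O`, which gives 4000 nM, and the furthest is compound 1 `CCOC(=O)c1cnc(-c2ccccc2)nc1NN1C(=O)C=C(C)C1=O`, which gives 100 nM. Compound 4 `CCOC(=O)c1cnc(Oc2ccccc2)nc1NN1C(=O)C=C(C)C1=O` differs from compound 3 by phenoxy in place of (furan-2-yl)carbonyl on an aromatic carbon. For the measured compounds named here, two measured steps bear on this change: a 7.0-fold higher number from compound 1 to compound 3 (0.85 log units; beyond the scatter) and a 5.7-fold lower number from compound 2 to compound 3 (0.76 log units; beyond the scatter); for comparison, a 40-fold higher number from compound 1 to compound 2 (1.60 log units; beyond the scatter). Phenoxy restores a six-membered ring of carbon only, so compound 4 is expected to move back toward the number of the phenyl compound 1, 100 nM. Compound 4 is therefore expected to show a modest step of a 2.3-fold lower number from compound 3 to compound 4 (0.37 log units; beyond the scatter) in this assay. The estimate for compound 4 is 300 nM, within 80 nM to 1500 nM.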

Compound 4, half-maximal inhibitory concentration: 15000 nM
Compound 4: the middle estimate sits 50-fold (1.70 log units) below what was measured; measured number above the stated range.
By their numbers in this assay, from the lowest: compound 1; then compound 3; then compound 2; then compound 4.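

In this assay, the single oxygen that sets phenoxy apart from phenyl matters greatly at this position: there is a 150-fold higher number from compound 1 to compound 4 (2.18 log units; beyond the scatter), so a six-membered aromatic ring of carbon only does not by itself bring back the low number of compound 1. Phenoxy also falls behind both other groups, with a 21-fold higher number from compound 3 to compound 4 (1.33 log units; beyond the scatter) and a 3.8-fold higher number from compound 2 to compound 4 (0.57 log units; beyond the scatter). No evidence is available that accounts for this loss. As far as these compounds go, whether an amine or a sulfur link in place of that oxygen would track phenyl or phenoxy remains open.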